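The source may report more compounds than this note shows. Statements on the series, on what has been measured and on what is new or still open speak of the compounds shown alone.

Measured so far in a functional assay for inhibition of sodium/hydrogen exchanger (Oryctolagus cuniculus); on this read-out lower numbers stand for stronger inhibition and higher numbers for weaker inhibition:
compound 1, `CCSc1cc(C)c(C(=O)N=C(N)N)cc1S(C)(=O)=O`, 5.9 nM
compound 2, `Cc1cc(OC(C)(C)C)c(S(C)(=O)=O)cc1C(=O)N=C(N)N`, 9.4 nM
compound 3, `Cc1cc(N)c(S(C)(=O)=O)cc1C(=O)N=C(N)N`, 16 nM

Compound 3 gives the highest of the three numbers: against compound 2 the gap is a 1.7-fold higher number from compound 2 to compound 3 (0.23 log units; within the scatter), within the scatter, while against compound 1 it is a 2.7-fold higher number from compound 1 to compound 3 (0.43 log units; beyond the scatter), a modest step beyond the scatter. Compound 4, `Cc1cc(Oc2cccnc2)c(S(C)(=O)=O)cc1C(=O)N=C(N)N`, is the unmeasured member of the series; ((pyridin-3-yl)oxy in place of amino on an aromatic carbon). Going by the values given here, two measured steps bear on this change in reverse. a 1.7-fold higher number from compound 2 to compound 3 (0.23 log units; within the scatter) shows that putting amino where tert-butoxy stood gives a slightly higher number, and a 2.7-fold higher number from compound 1 to compound 3 (0.43 log units; beyond the scatter) shows that putting amino where ethylsulfanyl stood gives a modestly higher one. Both are small, and (pyridin-3-yl)oxy is again an oxygen-linked group on the same aromatic carbon, so the direction should run the other way. For compound 4 a step of a 2.0-fold lower number from compound 3 to compound 4 (0.30 log units; within the scatter) is therefore expected in this assay, not clearly beyond the scatter. Compound 4 is estimated at 8 nM, with a range from 4 nM to 20 nM.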

Compound 4, half-maximal inhibitory concentration: 8.8 nM
Beside the measured number, compound 4's estimate is 1.1-fold (0.04 log units) below it; the range from low to high includes it.
By their numbers in this assay, from the lowest: compounds 1, 4, 2 and 3 (each within the scatter of the next, the first and the last beyond it).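

Until now this aromatic carbon carried only amino, tert-butoxy and ethylsulfanyl, none of them with a ring. In this assay, (pyridin-3-yl)oxy brings a six-membered aromatic ring onto it, and the read-out stays within the scatter whether the group replaces amino (a 1.8-fold lower number from compound 3 to compound 4 (0.26 log units; within the scatter)), tert-butyl on the same oxygen (a 1.1-fold lower number from compound 2 to compound 4 (0.03 log units; within the scatter)) or ethylsulfanyl (a 1.5-fold higher number from compound 1 to compound 4 (0.17 log units; within the scatter)), so an aromatic ring on this oxygen is accepted here without a change that can be told from the scatter. Nothing available explains why these groups read alike.

The compounds shown leave open whether the ring nitrogen counts at this carbon, which phenoxy or (pyridin-4-yl)oxy would address. As far as these compounds go, how far the position accepts still larger groups, such as benzyloxy or a longer alkoxy chain, also remains open.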